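Notes on the step from compound 3 to compound 4

The source may hold more compounds than are shown below. What is called first, only, known or untested is meant among the compounds shown, and "the series" means these compounds.

In a functional assay on OVCAR-3 cells (Homo sapiens) for cytotoxicity, read by sulforhodamine B assay (a lower number here means a stronger inhibitor of growth, a higher number a weaker inhibitor of growth), compound 1 `CC1=CC[C@@H]([C@@](C)(O)CCCC(C)(C)NC=S)CC1` gives 12100 nM, compound 2 `CC1=CC[C@@H]([C@@](C)(O)CCCC(C)(C)NC(=S)NN)CC1` gives 17200 nM and compound 3 `CC1=CC[C@@H]([C@@](C)(O)CCCC(C)(C)NC(=S)N/N=C\c2ccc(O)cc2)CC1` gives 6230 nM. Compound 3 thus stands within the scatter of compound 1 and beyond the scatter under compound 2. Compound 4 `CC1=CC[C@@H]([C@@](C)(O)CCCC(C)(C)NC(=S)N/N=C\c2ccc(Cl)cc2)CC1` differs from compound 3 by one change: chloro in place of hydroxy on an aromatic carbon. For the measured compounds named here, no measured step varies this substituent, so the evidence is indirect. The step that brought in the aromatic ring, a 2.8-fold lower number from compound 2 to compound 3 (0.44 log units; beyond the scatter), was modest, and a 1.4-fold higher number from compound 1 to compound 2 (0.15 log units; within the scatter) stayed within the scatter. The expected step, none beyond the scatter, is a 1.0-fold lower number from compound 3 to compound 4 (0.02 log units; within the scatter). For compound 4 the estimated value is 6000 nM, with an expected range of 2800 nM to 13000 nM.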

Compound 4, concentration for 50% growth inhibition: 6660 nM
Estimate against measurement, compound 4: 1.1-fold (0.05 log units) below; low and high end bracket the measured number.
By their numbers in this assay, from the lowest: compounds 3, 4, 1 and 2 (each within the scatter of the next, the first and the last beyond it).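

In this assay, 4-hydroxyphenyl to 4-chlorophenyl gives a 1.1-fold higher number from compound 3 to compound 4 (0.03 log units; within the scatter), so at this place on the ring the read-out does not separate hydroxy from chloro, even though chloro brings no hydrogen-bond donor. The aromatic group keeps its step with chloro too, with a 2.6-fold lower number from compound 2 to compound 4 (0.41 log units; beyond the scatter), as it did with hydroxy. No measured evidence bears on this result. As far as these compounds go, whether an amine, a carboxylic acid or a methoxy group at this place would shift the number stays open. So does the effect of a longer chain on the shared core.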